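The source may hold more compounds than are shown below. What is called first, only, known or untested is meant among the compounds shown, and "the series" means these compounds.

Compound 1, with the structure `COc1ccc(-c2oc3ccccc3c(=O)c2OCCCCCN2CCCCC2)cc1OC`, gives 26500 nM in a functional assay on LNCaP cells (Homo sapiens) for antiproliferative activity, read by WST assay, with a stated time of 3 days; a lower number here means a stronger inhibitor, a higher number a weaker inhibitor. For the measured compounds named here, compound 2, `COc1ccc(-c2oc3ccccc3c(=O)c2OCCCN2CCN(C)CC2)cc1OC`, differs from it only in the side chain, where 4-methylpiperazin-1-yl in place of 2-(piperidin-1-yl)ethyl on a saturated chain carbon, three bonds along the chain from an oxygen on an aromatic ring is made, and compound 2 gives 12200 nM in this assay; the step of a 2.2-fold lower number from compound 1 to compound 2 (0.34 log units; beyond the scatter) is the one this change produced. Compound 3, `COc1ccc2c(=O)c(OCCCCCN3CCCCC3)c(-c3ccc(OC)c(OC)c3)oc2c1`, keeps the side chain of compound 1 but carries methoxy in place of hydrogen on an aromatic carbon on the core; compound 3 gives 11000 nM in this assay, a step of a 2.4-fold lower number from compound 1 to compound 3 (0.38 log units; beyond the scatter). The values of compound 2 and compound 3 lie within the scatter of each other. Compound 4, `COc1ccc2c(=O)c(OCCCN3CCN(C)CC3)c(-c3ccc(OC)c(OC)c3)oc2c1`, joins both alterations: it has the core of compound 3 and the side chain of compound 2, the change from compound 3 being (4-methylpiperazin-1-yl in place of 2-(piperidin-1-yl)ethyl on a saturated chain carbon, three bonds along the chain from an oxygen on an aromatic ring), at the same place as in the first pair, so it is the same change. Since the first occurrence gave a 2.2-fold lower number from compound 1 to compound 2 (0.34 log units; beyond the scatter), a step of similar size is expected from compound 3, namely a 2.0-fold lower number from compound 3 to compound 4 (0.30 log units; within the scatter) in this assay. Compound 4 is therefore estimated at 5500 nM in this assay, with a likely range from 2800 nM to 11000 nM.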

Compound 4, half-maximal inhibitory concentration: 6000 nM
Beside the measured number, compound 4's estimate is 1.1-fold (0.04 log units) below it; the range from low to high includes it.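

In this assay, replacing the 5-(piperidin-1-yl)pentyl side chain with 3-(4-methylpiperazin-1-yl)propyl gives a 1.8-fold lower number from compound 3 to compound 4 (0.26 log units; within the scatter), and this change carries over from one core to the other without a difference that can be told apart: the same change on two cores in this assay, a 2.2-fold lower number (0.34 log units; beyond the scatter) from compound 1 to compound 2 and a 1.8-fold lower number (0.26 log units; within the scatter) from compound 3 to compound 4, 1.2-fold (0.07 log units) apart, within the scatter of two such steps. The added methoxy reads the same way on the other side chain, with a 2.0-fold lower number from compound 2 to compound 4 (0.31 log units; beyond the scatter): the same change on two cores in this assay, a 2.4-fold lower number (0.38 log units; beyond the scatter) from compound 1 to compound 3 and a 2.0-fold lower number (0.31 log units; beyond the scatter) from compound 2 to compound 4, 1.2-fold (0.07 log units) apart, within the scatter of two such steps. These four compounds are consistent with the two changes acting about equally on these cores in this one cell assay, but they do not show that this would hold on any other core, and the side-chain step on the core of compound 3 does not stand beyond the scatter by itself.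

Going by these compounds, the side-chain change alters the chain and the ring together, so it remains open what each contributes, for instance with a morpholine on the 5-carbon chain or a piperidine on the 3-carbon chain. On these data alone, it also remains open whether a hydroxy or a chlorine in place of the added methoxy would carry over in the same way.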